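The compounds below may be only part of what the source reports. "The series", "measured", "known", "first", "only" and "open" are said of these compounds alone.

Measured in a functional assay on HeLa cells (Homo sapiens) for antiproliferative activity, with a stated time of 48 h; a higher number here means a weaker inhibitor, a lower number a stronger inhibitor:
- Compound 1 (`C=C(Br)C(=O)Nc1ccc(/C=C/C(=O)c2ccc(Cl)c(Cl)c2)cc1`): 3200 nM
- Compound 2 (`Nc1ccc(/C=C/C(=O)c2ccccc2)cc1`): 36000 nM
- Compound 3 (`Nc1ccc(/C=C/C(=O)c2ccc(Cl)cc2)cc1`): 43000 nM

Compound 3, at 43000 nM, lies within the scatter of compound 2 and gives a clearly higher number than compound 1, at 3200 nM. Compound 4 (`Nc1ccc(/C=C/C(=O)c2ccc(Cl)c(Cl)c2)cc1`) differs from compound 3 by a chloro in place of hydrogen on an aromatic carbon, ortho to a chloro group: chloro in place of hydrogen on an aromatic carbon. Among the compounds with values here, the only measured step of this kind is a 1.2-fold higher number from compound 2 to compound 3 (0.08 log units; within the scatter), so it offers thin support, but it suggests no change beyond the scatter in this assay. The expected step is a 1.3-fold lower number from compound 3 to compound 4 (0.13 log units; within the scatter). For compound 4 the estimated value is 32000 nM, with an expected range of 12000 nM to 60000 nM.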

Compound 4, half-maximal inhibitory concentration: 31000 nM
Compound 4: middle estimate off by 1.0-fold (0.01 log units), on the high side; low and high end bracket the measured number.
By their numbers in this assay, from the lowest: compound 1; then compounds 4, 2 and 3 (each within the scatter of the next).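

In this assay, a chloro ortho to a chloro group brings no change beyond the scatter, with a 1.4-fold lower number from compound 3 to compound 4 (0.14 log units; within the scatter), so this second chloro step stays as small as the first. The same compound gives the first clear single-place contrast on the nitrogen: hydrogen in place of (1-bromoethenyl)carbonyl brings a 9.7-fold higher number from compound 1 to compound 4 (0.99 log units; beyond the scatter). No supporting data explain either step. Open, as far as these compounds go, is whether a methoxy or a nitrile at this ring position would also stay within the scatter, and whether a plain acetyl on the nitrogen would match compound 1.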